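The compounds below may be only part of what the source reports. "The series", "measured", "known", "first", "only" and "open" are said of these compounds alone.

Of the compounds shown here, three have so far been measured in a physicochemical assay for lipophilicity; a higher number here means a more lipophilic compound, a lower number a more polar compound. Compound 1 `O=S(=O)(Nc1ncccn1)c1ccc2c(c1)CC[C@@H]2c1ccc(C(F)(F)F)cc1-c1ccc(F)nc1` gives 3.2, and compound 2 `Cc1nc(-c2cc(C(F)(F)F)ccc2[C@H]2CCOc3cc(S(=O)(=O)Nc4nccs4)ccc32)co1` gives 2.9. These two numbers lie within the scatter of each other, so compound 1 shares the upper end of the set with compound 2. Compound 3 `Cn1nccc1-c1cc(C(F)(F)F)ccc1[C@H]1CCOc2cc(S(=O)(=O)Nc3cnccn3)ccc21` gives 1.8, a gap from compound 1 that is beyond the scatter. Within the data shown here, these three compounds differ in several places at once, so no measured pair isolates the effect of a single change.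

Compound 4 `Cc1ccc(-c2cc(C(F)(F)F)ccc2[C@H]2CCc3cc(S(=O)(=O)Nc4ncccn4)ccc32)cn1` is still unmeasured. It differs from compound 1 at one spot: methyl in place of fluoro on an aromatic carbon. This puts methyl in place of fluoro on an aromatic carbon, turning 6-fluoropyridin-3-yl into 6-methylpyridin-3-yl. Among the measured compounds shown here, with no measured step to draw on, the starting point is compound 1 at 3.2, and no shift beyond the scatter is expected in this assay. The expected step is no change at the digits printed from compound 1 to compound 4 (within the scatter). Compound 4 is therefore estimated at 3.2, with an expected range from 2.8 to 3.6.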

Compound 4, distribution coefficient: 2.8
Beside the measured number, compound 4's estimate is 0.40 log units above it; the range from low to high includes it.
By their numbers in this assay, from the lowest: compound 3; then compounds 4, 2 and 1 (each within the scatter of the next, the first and the last beyond it).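

Among these compounds, the step gives the first reading of a single change in this set: in this assay, methyl in place of fluoro on this aromatic carbon, next to the ring nitrogen, gives a number 0.40 log units lower from compound 1 to compound 4 (beyond the scatter) while the rest of the molecule stays the same. The two groups each count one heavy atom and neither brings a hydrogen-bond donor or acceptor, yet the reading moves, so this position is not silent in this assay despite those matching counts. Nothing measured here accounts for the direction of the step.

On these data alone, how other groups on this carbon, such as an amine or a carboxylic acid, would read in this assay stays open. So does whether the same swap would give a similar step on structures like compound 2 and compound 3, which differ from compound 1 in several places.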